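A few compounds are considered here, and "the series" means these few. Any claim that something is new, unique, unknown or untested is made for them only; others in the source may bear on it.

Measured so far:
- Compound 1 `CN(C)C(=S)N/N=C/c1ccc2ccccc2n1` gives 20 nM in a functional assay on HT-29 cells (Homo sapiens) for antiproliferative activity, read by sulforhodamine B assay, with a stated time of 72 h; a higher number here means a weaker inhibitor, a lower number a stronger inhibitor.
- Compound 2 `Fc1ccccc1NC(=S)N/N=C/c1ccc2ccccc2n1` gives only a limit of the assay, > 100000 nM, in this assay.
- Compound 3 `CN(C)C(=S)N/N=C/c1cnc2ccccc2n1` gives 450 nM in this assay.

Among the measured compounds shown here, compound 2 is the one with no number at all: its result is a limit, the value sitting at the limit of > 100000 nM in this assay, at which 1 of the 3 values shown sits. Compound 1 and compound 3 both give real numbers, and both carry a dimethyl thiourea end rather than the aryl thiourea of compound 2.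

The next compound, compound 4 `Cc1ccccc1NC(=S)N/N=C/c1ccc2ccccc2n1`, differs from compound 2 in one place: methyl in place of fluoro on an aromatic carbon. The aryl ring and the rest of the molecule stay the same. For the measured compounds named here, no measured pair here changes only this group, so there is no step on record to lean on; the only guide is that compound 2 itself returned no number.

In this assay, the step from compound 2 to compound 4 is expected to be none beyond the scatter, most likely ending again at a limit. Compound 4 is therefore estimated at 100000 nM, with a range from 10000 nM to 300000 nM, a change of a number no higher from compound 2 to compound 4 (the limit leaves the size open) that carries little weight since the starting point is itself a limit.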

Compound 4, half-maximal inhibitory concentration: 42300 nM
Compound 4: the middle estimate sits 2.4-fold (0.37 log units) above what was measured; the measured number falls inside the stated range.
By their numbers in this assay, from the lowest: compound 1; then compound 3; then compound 4. At a limit, above all of these: compound 2.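

In this assay, compound 4 gives 42300 nM, the only real number shown so far for a compound with an aryl thiourea end. The change from 2-fluorophenyl to 2-methylphenyl gives an at least 2.3-fold lower number from compound 2 to compound 4 (0.37 log units; beyond the scatter), so swapping a single heavy atom on this aromatic carbon, ortho to a large group, is enough to bring the result off the limit. The true size of the step stays unknown because compound 2 has only a limit of the assay, not a number: the limit of > 100000 nM in this assay, at which 1 of the 4 values shown sits.

The compounds shown leave open how this position responds to other groups, such as chloro, methoxy or an amine. They also leave open whether a methyl placed elsewhere on the aryl ring would give a similar number.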